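A few compounds are considered here, and "the series" means these few. Any claim that something is new, unique, unknown or untested is made for them only; others in the source may bear on it.

The series is read in a functional assay on Ramos cells (Homo sapiens) for antiproliferative activity, read by CCK-8 assay, with a stated time of 72 h, tested at 40 uM; on this read-out higher numbers stand for more inhibition at the one concentration tested (going by the name of the read-out) and lower numbers for less inhibition. Compound 1 `CCOC(=O)c1sc(-c2cccc(NC(=O)c3ccccc3F)c2)nc1Nc1ccc(N2CCN(C)CC2)cc1` gives 96.4%. Compound 2 `CN1CCN(c2ccc(Nc3nc(-c4cccc(NC(=O)c5ccccc5)c4)sc3C(N)=O)cc2)CC1` differs from compound 1 both on the shared core and in the benzamido group; in this assay compound 2 gives 98.1%. The two values lie within the usual scatter of each other, so this read-out does not separate the two compounds; both numbers are high at the single concentration tested. Compound 3 `CN1CCN(c2ccc(Nc3nc(-c4cccc(NC(=O)c5ccccc5F)c4)sc3C(N)=O)cc2)CC1` has not yet been measured. It differs from compound 2 by fluoro in place of hydrogen on an aromatic carbon. Compound 1 already carries the same fluoro, with a different group on the shared core, and its value sits close to that of compound 2. Among the measured compounds shown here, no measured pair separated by this change alone is available. The expected step is a number 1.1 percentage points lower from compound 2 to compound 3 (within the scatter), no larger than the scatter and in no particular direction, given that compound 1 with the fluoro present gives 96.4%. Compound 3 is therefore estimated at 97%, between 91% and 99.5%.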

Compound 3, a percentage reported as inhibition, at one concentration (the size of the read-out at that concentration, not a potency): 95.5%
The estimate for compound 3 lay 1.5 percentage points above the measured number; low and high end bracket the measured number.
By their numbers in this assay, from the lowest: compounds 3, 1 and 2 (each within the scatter of the next).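

In this assay, fluoro in place of hydrogen on an aromatic carbon can now be read as a single change: a number 2.6 percentage points lower from compound 2 to compound 3 (within the scatter), so phenyl and 2-fluorophenyl are not separated at this position. The group on the carbonyl carbon of the shared core can also be read alone, with amino in place of ethoxy giving a number 0.9 percentage points lower from compound 1 to compound 3 (within the scatter), so neither single change moves the read-out beyond the scatter. No measurement available here accounts for either step.

All three compounds sit high at the one concentration tested, so these values leave open whether differences in potency exist among them. Also open, as far as these compounds go, is how the read-out responds to chloro or methoxy in place of the fluoro, or to hydroxy or methylamino in place of amino on the carbonyl carbon.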